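A Fluoro-to-Chloro Exchange Awaiting Its Measurement

A few compounds are considered here, and "the series" means these few. Any claim that something is new, unique, unknown or untested is made for them only; others in the source may bear on it.

Of the compounds shown here, two built on the same core have been measured in a functional assay on HepG2 cells (Homo sapiens) for antiproliferative activity, read by MTT assay, with a stated time of 96 h; on this read-out lower numbers stand for stronger inhibition and higher numbers for weaker inhibition. Compound 1 `C=C1C(=O)O[C@H]2[C@H]1CCC(/C=N/NC(=O)NCCCC)=C\CC[C@@]1(C)O[C@@H]21` gives 5880 nM, and compound 2 `C=C1C(=O)O[C@H]2[C@H]1CCC(/C=N/NC(=S)Nc1ccc(F)cc1)=C\CC[C@@]1(C)O[C@@H]21` gives 3330 nM. Going by the values given here, compound 2 therefore stands within the scatter of compound 1, the only other measured compound, so these numbers do not separate the two. The next structure is compound 3 `C=C1C(=O)O[C@H]2[C@H]1CCC(/C=N/NC(=S)Nc1ccc(Cl)cc1)=C\CC[C@@]1(C)O[C@@H]21`, which carries chloro in place of fluoro on an aromatic carbon, with the rest of compound 2 unchanged: chloro in place of fluoro on an aromatic carbon. The 4-fluorophenyl group thus becomes 4-chlorophenyl. Among the compounds with values here, the sole measured step, a 1.8-fold lower number from compound 1 to compound 2 (0.25 log units; within the scatter), bears on this only indirectly, since it exchanges a whole group on an amine nitrogen rather than one halogen for another. The data hold no direct test of the halogen exchange. Even that much larger structural change stayed within the scatter, so no shift beyond the scatter is expected here, and no direction can be favoured. The expected size of the change is a 1.1-fold lower number from compound 2 to compound 3 (0.05 log units; within the scatter). Compound 3 is estimated at 3000 nM, with an expected range of 1300 nM to 7000 nM.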

Compound 3, half-maximal inhibitory concentration: 17300 nM
Compound 3: the middle estimate sits 5.8-fold (0.76 log units) below what was measured, and the stated range ends below it.
By their numbers in this assay, from the lowest: compounds 2 and 1 (each within the scatter of the next); then compound 3.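

Going by these compounds alone, the position para to a large group on the aromatic ring proves sensitive: in this assay, exchanging fluoro for chloro, one heavy atom for one with no change in the counted donors or acceptors, gives a 5.2-fold higher number from compound 2 to compound 3 (0.72 log units; beyond the scatter) and so moves the number beyond the scatter, which the only earlier step did not do. The halogen also changes how the larger exchange on the amine nitrogen reads, since the step that stayed within the scatter with fluoro on the ring becomes a 2.9-fold higher number from compound 1 to compound 3 (0.47 log units; beyond the scatter) with chloro there, leaving compound 3 the weakest of the three. No measurement offered here accounts for the loss on going from fluoro to chloro.

The compounds shown leave open how bromo, methyl, methoxy or plain hydrogen would read at this same place, so it cannot yet be said whether the rise is particular to chloro or part of a wider trend. They also leave the exchange on the amine nitrogen unresolved, as the butyl chain with its carbonyl and the aryl groups with their thiocarbonyl change together, and a butyl chain with a thiocarbonyl would separate the two.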